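Benzyl for Methyl at One Ester of Compound 1

The compounds below may be only part of what the source reports. "The series", "measured", "known", "first", "only" and "open" are said of these compounds alone.

compound 1: `COC(=O)C1=C(C)NC(C)=C(C(=O)OC)C1c1[nH]cnc1Cl` — 1200 nM
compound 2: `CC1=C(C(=O)OCc2ccccc2)C(c2nc[nH]c2Cl)C(C(=O)OCc2ccccc2)=C(C)N1` — 41.7 nM

In an assay on isolated protein for inhibition of Voltage-dependent L-type calcium channel subunit alpha-1C (Cavia porcellus) (a lower number here means a stronger inhibitor, a higher number a weaker inhibitor), compound 1 gives 1200 nM, the highest of the two numbers shown. Compound 2 gives 41.7 nM in this assay, a lower number beyond the scatter. Compound 3 `COC(=O)C1=C(C)NC(C)=C(C(=O)OCc2ccccc2)C1c1[nH]cnc1Cl` differs from compound 1 by phenyl in place of hydrogen on a saturated chain carbon bound to an oxygen next to a carbonyl group. Going by the values given here, no measured pair shows exactly this single change; compound 2 carries the methyl-to-benzyl change at two ester groups. A drop beyond the scatter is therefore expected, a 5.5-fold lower number from compound 1 to compound 3 (0.74 log units; beyond the scatter). Compound 3 is expected to give 220 nM in this assay, within 70 nM to 700 nM.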

Compound 3, half-maximal inhibitory concentration: 93.3 nM
For compound 3 the middle estimate is 2.4-fold (0.37 log units) above the measured one, within the range that was stated.
By their numbers in this assay, from the lowest: compound 2; then compound 3; then compound 1.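

Methyl to benzyl at a single ester is enough on its own for a large change in this assay as the number falls a 13-fold lower number from compound 1 to compound 3 (1.11 log units; beyond the scatter) with the other ester still methyl. Nothing measured on these compounds accounts for the size of this step. Still open, on these data alone, is whether the gain needs the phenyl ring itself or only a larger ester group. An ethyl ester or a longer chain ester at this place would separate the two, and a pyridine ring in place of the phenyl would test the ring.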